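The compounds below may be only part of what the source reports. "The series", "measured", "known", "first", "only" and "open" are said of these compounds alone.

Measured compounds: compound 1 `Fc1cccc(F)c1Cn1c(-c2c(F)cccc2F)nc2c(Br)cccc21`, which in a toxicity assay on CCRF-CEM cells (Homo sapiens) for cytotoxicity (on this read-out lower numbers stand for higher toxicity in this test and higher numbers for lower toxicity in this test), gives 24.5 uM. Compound 2 `CN(C)c1cccc2c1nc(-c1c(F)cccc1F)n2Cc1c(F)cccc1F`, which in this assay gives > 100 uM, a limit of the assay rather than a number, sitting at the limit of > 100 uM in this assay, at which 1 of the 2 values shown sits. Compound 2 thus stands at the upper end of the numbers shown. Within the data shown here, the only measured step, an at least 4.0-fold higher number from compound 1 to compound 2 (0.61 log units; beyond the scatter), raised the number. Compound 3 `[N-]=[N+]=NCc1cccc2c1nc(-c1c(F)cccc1F)n2Cc1c(F)cccc1F` arises by azidomethyl in place of dimethylamino on an aromatic carbon. Among the measured compounds shown here, no measured step involves azidomethyl, so nothing bears directly on this change. Compound 3 is expected to show an at least 1.6-fold lower number from compound 2 to compound 3 (0.22 log units; that floor lies within the scatter), with an estimated value of 60 uM, between 20 uM and 200 uM.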

Compound 3, half-maximal toxic concentration: > 100 uM
Compound 3: a limit, no number; the forecaster's own chance of this, stated with the estimate: 45%; middle value at least 1.6-fold (0.22 log units) from the limit.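

In this assay compound 3 gives > 100 uM, a limit of the assay and not a number. Azidomethyl in place of bromo gives an at least 4.0-fold higher number from compound 1 to compound 3 (0.61 log units; beyond the scatter), so a second group on this aromatic carbon, besides dimethylamino, also gives a higher number. The step between compound 2 and compound 3 cannot be read, and both compounds sit at the same limit: the limit of > 100 uM in this assay, at which 2 of the 3 values shown sit.

On these data alone, whether dimethylamino and azidomethyl differ at all remains open, as neither compound has a number. Also open, as far as these compounds go, is whether a primary amine or a carboxylic acid on this aromatic carbon would also give a higher number than bromo.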